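This account rests on a few compounds, and the source may have more. Where it says the series, first, only, none or still open, it means among the compounds named here.

Of the compounds shown here, three of a shared core have been measured. Compound 1 `CC1SC(c2cccc(C(=O)NCCCCc3ccccc3)c2)N(c2ccc(C3CC3)cc2)C1=O` in a physicochemical assay for solubility, read by turbidimetry, measured as kinetic solubility, at pH 7.4 (on this read-out lower numbers stand for lower solubility and higher numbers for higher solubility), gives 2000 nM. Among the measured compounds shown here, compound 3 `COc1ccccc1N1C(=O)C(C)SC1c1cccc(C(=O)NCCCCc2ccccc2)c1` gives 10000 nM, and the single change between them, 2-methoxyphenyl in place of 4-cyclopropylphenyl on an amide-type nitrogen in a ring, produced a 5.0-fold higher number from compound 1 to compound 3 (0.70 log units; beyond the scatter). Compound 2 `O=C(NCCCCc1ccccc1)c1cccc(C2SCC(=O)N2c2cccc(-c3c[nH]nn3)c2)c1` gives 20000 nM; of the three numbers it is the largest, though compound 3 sits within the scatter of it and only compound 1 lies beyond.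

Compound 4 `O=C(NCCCCc1ccccc1)c1cccc(C2SCC(=O)N2c2ccccn2)c1` is not yet measured. It differs from compound 2 in one place: a group of 6 heavy atoms (5 carbon, 1 nitrogen; one six-membered aromatic ring with 1 hetero atom) in place of a group of 11 heavy atoms (8 carbon, 3 nitrogen; one five-membered aromatic ring with 3 hetero atoms, one six-membered aromatic ring of carbon only), on an amide-type nitrogen in a ring. For the measured compounds named here, the only measured step that bears on this change is the one from compound 1 to compound 3, which also swaps the group on the amide-type nitrogen in a ring and moved the number by a 5.0-fold higher number from compound 1 to compound 3 (0.70 log units; beyond the scatter). That precedent shows a swap at this position can shift solubility by a modest amount, but the groups involved are different, so the direction is uncertain. In this assay compound 4 is expected to land close to compound 2, with any movement likely within the scatter, as a step of a 1.3-fold lower number from compound 2 to compound 4 (0.12 log units; within the scatter). Compound 4 is therefore estimated at 15000 nM, with a range from 5000 nM to 40000 nM.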

Compound 4, solubility: 20000 nM
For compound 4 the middle estimate is 1.3-fold (0.12 log units) below the measured one; low and high end bracket the measured number.
By their numbers in this assay, from the lowest: compound 1; then compounds 3, 2 and 4 (each within the scatter of the next).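

In this assay the swap on the amide-type nitrogen in a ring gave no change at the digits printed from compound 2 to compound 4 (within the scatter), even though pyridin-2-yl, with 6 heavy atoms and 0 hydrogen-bond donors, took the place of a group of 11 heavy atoms with 1 hydrogen-bond donor. The earlier step at this nitrogen, a 5.0-fold higher number from compound 1 to compound 3 (0.70 log units; beyond the scatter), had shown only that a swap here can move the number; this pair shows that a swap here can also leave it in place, and that a number of this size on this core does not depend on the hydrogen-bond donor or the five-membered aromatic ring of the larger group. No measurement of another kind is available to account for this result.

The compounds shown leave open how a morpholine, a carboxylic acid or a longer chain ending in an amine on this nitrogen would read in this assay. On these data alone, it also remains open whether pyridin-2-yl would read the same way on the methyl-bearing core of compound 1 and compound 3, where the group on this nitrogen did move the number.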